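The compounds below may be only part of what the source reports. "The series", "measured", "known", "first", "only" and "open" are said of these compounds alone.

Measured so far:
- compound 1 `COc1ccc([C@@H]2CC(=O)c3c(O)cc(OCc4cn(Cc5ccc(C(F)(F)F)cc5)nn4)cc3O2)cc1O`: 17700 nM
- compound 2 `COc1ccc([C@@H]2CC(=O)c3c(O)cc(OCc4cn(Cc5cccc(Cl)c5)nn4)cc3O2)cc1O`: 18200 nM
- compound 3 `COc1ccc([C@@H]2CC(=O)c3c(O)cc(OCc4cn(Cc5ccccc5C#N)nn4)cc3O2)cc1O`: 14600 nM

In a functional assay on RAW264.7 cells (Mus musculus) for inhibition, read by Griess assay, with stated times of 2 h and 24 h (on this read-out higher numbers stand for weaker inhibition and lower numbers for stronger inhibition), compound 3 cannot be separated from the other two, as a 1.2-fold lower number from compound 1 to compound 3 (0.08 log units; within the scatter) and a 1.2-fold lower number from compound 2 to compound 3 (0.10 log units; within the scatter) both stay within the scatter. The same holds for a 1.0-fold higher number from compound 1 to compound 2 (0.01 log units; within the scatter).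

The next compound is compound 4 `COc1ccc([C@@H]2CC(=O)c3c(O)cc(OCc4cn(C)nn4)cc3O2)cc1O`, and the change is hydrogen in place of 2-cyanophenyl on a saturated chain carbon bound to an aromatic nitrogen. In words, this is hydrogen in place of 2-cyanophenyl on a saturated chain carbon bound to an aromatic nitrogen, or 2-cyanobenzyl to methyl when cut one bond further out.

The three measured steps only exchange one substituted phenyl for another. Within the data shown here, no measured compound lacks that ring, so these steps bear on the new change only indirectly, and the direction below is a tentative expectation. It starts from compound 3 at 14600 nM and points to a somewhat higher number in this assay. The expected step is a 1.7-fold higher number from compound 3 to compound 4 (0.23 log units; within the scatter), which may prove no larger than the scatter. For compound 4 the estimated value is 25000 nM, with an expected range from 11000 nM to 55000 nM.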

Compound 4, half-maximal inhibitory concentration: 15200 nM
For compound 4 the middle estimate is 1.6-fold (0.22 log units) above the measured one; the range from low to high includes it.
By their numbers in this assay, from the lowest: compounds 3, 4, 1 and 2 (each within the scatter of the next).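

In this assay, compound 4, with hydrogen in place of the aryl group, cannot be separated from any of the three aryl compounds (a 1.0-fold higher number from compound 3 to compound 4 (0.02 log units; within the scatter)) (a 1.2-fold lower number from compound 2 to compound 4 (0.08 log units; within the scatter)) (a 1.2-fold lower number from compound 1 to compound 4 (0.07 log units; within the scatter)). The earlier steps only compared one substituted phenyl with another, whereas these show that, on a saturated chain carbon bound to an aromatic nitrogen, 2-cyanophenyl, 3-chlorophenyl and 4-(trifluoromethyl)phenyl are each not separated from plain hydrogen, so among these four compounds the ring is not needed for a number at this level. Nothing available explains this flat result.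

Going by these compounds, it remains open whether any group at this position can move the number beyond the scatter. A carboxylic acid, an amine or a longer alkyl chain in place of the methyl of compound 4 would test that.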